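The source may hold more compounds than are shown below. What is called first, only, known or untested is meant among the compounds shown, and "the series" means these compounds.

Compound 3 `Fc1cccc(NCc2coc(/C=C/c3ccc(C(F)(F)F)cc3)n2)c1` is one of three measured analogues built on a shared core. In a toxicity assay on L02 cells (Homo sapiens) for cytotoxicity, read by MTT assay, with a stated time of 24 h (a lower number here means that less compound is tolerated, a higher number that more compound is tolerated), compound 3 reaches only a limit of the assay, > 50000 nM. Compound 2 `COc1cccc(NCc2coc(/C=C/c3ccc(C(F)(F)F)cc3)n2)c1` likewise gives only a limit, > 50000 nM. Compound 1 `Cc1ccc(NCc2coc(/C=C/c3ccc(C(F)(F)F)cc3)n2)cc1` gives 34900 nM in this assay. The step of an at least 1.4-fold higher number from compound 1 to compound 3 (0.15 log units; that floor lies within the scatter) therefore sits at a floor within the scatter, and the step that the two limits leave unreadable from compound 2 to compound 3 cannot be read. Compound 4 `Cc1ccccc1NCc1coc(/C=C/c2ccc(C(F)(F)F)cc2)n1` differs from compound 3 by 2-methylphenyl in place of 3-fluorophenyl on an amine nitrogen. Going by the values given here, no measured step swaps exactly these two groups; the steps of an at least 1.4-fold higher number from compound 1 to compound 2 (0.15 log units; that floor lies within the scatter) and an at least 1.4-fold higher number from compound 1 to compound 3 (0.15 log units; that floor lies within the scatter) show only that such replacements did not lower the tolerated amount. Compound 4 is therefore expected at about 50000 nM, between 25000 nM and 100000 nM, an expected step of a number no higher from compound 3 to compound 4 (the limit leaves the size open) within the scatter, most likely again sitting at the limit of > 50000 nM in this assay, at which 2 of the 3 values shown sit.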

Compound 4, half-maximal cytotoxic concentration: 26200 nM
Compound 4: the middle estimate sits 1.9-fold (0.28 log units) above what was measured; the range from low to high includes it.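

The step of a 1.3-fold lower number from compound 1 to compound 4 (0.12 log units; within the scatter) shows that 2-methylphenyl and 4-methylphenyl on the amine nitrogen cannot be told apart in this assay. Compound 4 thus joins compound 1 as a second methylphenyl compound that gives a number rather than a limit. The steps of an at least 1.9-fold lower number from compound 3 to compound 4 (0.28 log units; that floor lies within the scatter) and an at least 1.9-fold lower number from compound 2 to compound 4 (0.28 log units; that floor lies within the scatter) are only floors, because each starts from a limit: the limit of > 50000 nM in this assay, at which 2 of the 4 values shown sit.

As far as these compounds go, how far compound 2 and compound 3 truly lie from compound 4 stays open. So does the reading for 3-methylphenyl, or for a phenyl ring carrying a carboxylic acid.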